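Furan-2-yl in place of phenyl on the shared core

The compounds below may be only part of what the source reports. "The series", "measured", "known", "first", "only" and "open" are said of these compounds alone.

Compound 1 `Oc1cccc(-c2cc(-c3cccnc3)nc(-c3cccc(Cl)c3)c2)c1` — "not determined" (no result reported)
Compound 2 `Oc1ccc(-c2cc(-c3ccccc3)nc(-c3ccccc3Cl)c2)cc1` — 4990 nM
Compound 3 `Oc1ccc(-c2cc(-c3ccc(Cl)cc3)nc(-c3cccnc3)c2)cc1` — 20700 nM

Three compounds of one series were examined in a functional assay on HCT-15 cells (Homo sapiens) for cytotoxicity, read by CCK-8 assay and cell counting, with a stated time of 2 days; a lower number here means a stronger inhibitor, a higher number a weaker inhibitor. Compound 1 has no single number in this assay. Compound 2 gives 4990 nM and holds the lowest number of the two that are known. Its nearest neighbour is compound 3, which gives 20700 nM, a gap that lies beyond the usual scatter of this assay. The two measured compounds differ in more than one place, so no single step can be read from their pair.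

Compound 4 `Oc1ccc(-c2cc(-c3ccco3)nc(-c3ccccc3Cl)c2)cc1` is the next member. It differs from compound 2 in one place: furan-2-yl in place of phenyl on an aromatic carbon. Within the data shown here, no measured pair shows this exact change, so the expectation rests only on the number of compound 2. A step of modest size is expected from compound 2 to compound 4, most likely within the scatter, with the direction left open, giving a 1.2-fold higher number from compound 2 to compound 4 (0.08 log units; within the scatter). On that basis compound 4 is estimated at 6000 nM in this assay, within a range from 1500 nM to 25000 nM.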

Compound 4, half-maximal inhibitory concentration: 5460 nM
Beside the measured number, compound 4's estimate is 1.1-fold (0.04 log units) above it, within the range that was stated.
By their numbers in this assay, from the lowest: compounds 2 and 4 (each within the scatter of the next); then compound 3.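

In this assay, among these compounds, furan-2-yl in place of phenyl on an aromatic carbon next to the ring nitrogen gives a 1.1-fold higher number from compound 2 to compound 4 (0.04 log units; within the scatter), the only step that can be read from a single difference. At this place, meta to a 2-chlorophenyl group and meta to a 4-hydroxyphenyl group, a six-membered aromatic ring of carbon only and a five-membered aromatic ring with 1 hetero atom and 1 hydrogen-bond acceptor thus give numbers that cannot be told apart in this measurement. No measured evidence bears on this result.

The compounds shown carry only these two aromatic rings at this place, so it remains open whether an amine, a carboxylic acid or a longer alkyl chain there would also stay within the scatter of compound 2. On these data alone, it also remains open whether the same exchange would read alike with the other groups of compound 3 on the shared core, since a single step cannot show how far this result extends.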